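Dithiocarbamate Chromones: Swapping Diisopropylamino for Morpholine

The source may hold more compounds than are shown below. What is called first, only, known or untested is meant among the compounds shown, and "the series" means these compounds.

Measured so far:
compound 1 `Cc1ccc2c(=O)c(CSC(=S)N(C(C)C)C(C)C)coc2c1`: 240 nM
compound 2 `CC(C)N(C(=S)SCc1cc(=O)c2ccccc2o1)C(C)C`: > 40000 nM
compound 3 `Cc1ccc2c(=O)c(CSC(=S)N3CCOCC3)coc2c1`: 5500 nM

Of the compounds shown here, three have been tested in a functional assay on MDA-MB-435S cells (Homo sapiens) for antiproliferative activity, read by MTT assay, with a stated time of 72 h; on this read-out lower numbers stand for stronger inhibition and higher numbers for weaker inhibition. Compound 1 gives 240 nM. Compound 3 gives 5500 nM. For compound 2 the assay returned only a limit, > 40000 nM, not a number. Compound 2 and compound 1 carry different cores; the difference between the two cores is not broken down here. Compound 3 differs from compound 1 by morpholin-4-yl in place of diisopropylamino on a thiocarbonyl carbon. That single change produced a step of a 23-fold higher number from compound 1 to compound 3 (1.36 log units; beyond the scatter).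

Compound 4 `O=c1cc(CSC(=S)N2CCOCC2)oc2ccccc12` is still to be measured in this assay. It differs from compound 2 by morpholin-4-yl in place of diisopropylamino on a thiocarbonyl carbon, the same change at the same place. The starting point is different, however, since compound 2 already sits at the limit of > 40000 nM in this assay, at which 1 of the 3 values shown sits. The step expected here is a step that the limit leaves unreadable from compound 2 to compound 4. This expectation rests on the measured step of a 23-fold higher number from compound 1 to compound 3 (1.36 log units; beyond the scatter) together with the limit of > 40000 nM in this assay, at which 1 of the 3 values shown sits. Compound 4 is therefore expected near 60000 nM, within 30000 nM to 200000 nM, and most likely it will again be reported only as a limit.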

Compound 4, half-maximal inhibitory concentration: 22200 nM
For compound 4 the middle estimate is 2.7-fold (0.43 log units) above the measured one, outside the stated range (below it).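

Compound 2 is reported only as a limit, > 40000 nM, and not as a number. In this assay, the swap of diisopropylamino for morpholin-4-yl therefore reads as an at least 1.8-fold lower number from compound 2 to compound 4 (0.25 log units; that floor lies within the scatter), which gives only a floor for this step and not its true size. Even so, the change does not carry over from one core to the other as a fixed step, although two cores cannot show how it would behave on a third core, nor why the two results part ways: the same change on two cores in this assay, a 23-fold higher number (1.36 log units; beyond the scatter) from compound 1 to compound 3 and an at least 1.8-fold lower number (0.25 log units; that floor lies within the scatter) from compound 2 to compound 4, at least 41-fold (1.61 log units) apart, beyond the scatter of two such steps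

Going by these compounds, it remains open whether other groups on the same thiocarbonyl carbon, such as diethylamino or a piperidine ring, would follow diisopropylamino or morpholin-4-yl on each core. The compounds shown also leave open which feature of the two cores decides how strongly the swap acts, since none of the pairs here changes the core while keeping the amine the same in a way that can be read as a number for both amines.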